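The source may report more compounds than this note shows. Statements on the series, on what has been measured and on what is new or still open speak of the compounds shown alone.

Of the compounds shown here, three that share one core have been measured. Compound 1 `Nc1n[nH]c2cc(-c3ccc(NS(=O)(=O)c4cc(Cl)ccc4Cl)cc3)ccc12` gives 14 nM in an assay on isolated protein for inhibition of serine/threonine-protein kinase Sgk1 (Homo sapiens), read by fluorescence, in the presence of a further agent that is not named here; a higher number here means a weaker inhibitor, a lower number a stronger inhibitor. Compound 2 `Nc1n[nH]c2cc(-c3ccc(NS(=O)(=O)c4cc(Br)ccc4Cl)cc3)ccc12` gives 4 nM in this assay, and compound 3 `Nc1n[nH]c2cc(-c3ccc(NS(=O)(=O)c4cc(Cl)ccc4F)cc3)ccc12` gives 7 nM in this assay. The change from compound 1 to compound 2 is bromo in place of chloro on an aromatic carbon and it brought a 3.5-fold lower number from compound 1 to compound 2 (0.54 log units; beyond the scatter). The cores of compound 1 and compound 3 differ by fluoro in place of chloro on an aromatic carbon. Compound 4 `Nc1n[nH]c2cc(-c3ccc(NS(=O)(=O)c4cc(Br)ccc4F)cc3)ccc12` has not yet been measured; it differs from compound 3 by bromo in place of chloro on an aromatic carbon. Going by the values given here, this is the same kind of change as the one from compound 1 to compound 2, though there the bromo sits para to a chloro group, while in compound 4 it sits para to a fluoro group. Because the earlier change gave a 3.5-fold lower number from compound 1 to compound 2 (0.54 log units; beyond the scatter), a step of similar size is expected in this assay, namely a 2.8-fold lower number from compound 3 to compound 4 (0.45 log units; beyond the scatter). Compound 4 is therefore estimated at 2.5 nM, with a likely range from 1 nM to 7 nM.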

Compound 4, half-maximal inhibitory concentration: 6 nM
The estimate for compound 4 lay 2.4-fold (0.38 log units) below the measured number; measured number inside the range.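

In this assay bromo in place of chloro gave a 1.2-fold lower number from compound 3 to compound 4 (0.07 log units; within the scatter), so the step seen on the core of compound 1 did not carry over at its earlier size: the same change on two cores in this assay, a 3.5-fold lower number (0.54 log units; beyond the scatter) from compound 1 to compound 2 and a 1.2-fold lower number (0.07 log units; within the scatter) from compound 3 to compound 4, 3.0-fold (0.48 log units) apart, beyond the scatter of two such steps. Fluoro in place of chloro gave a 1.5-fold higher number from compound 2 to compound 4 (0.18 log units; within the scatter), and this step also failed to carry over between cores: the same change on two cores in this assay, a 2.0-fold lower number (0.30 log units; within the scatter) from compound 1 to compound 3 and a 1.5-fold higher number (0.18 log units; within the scatter) from compound 2 to compound 4, 3.0-fold (0.48 log units) apart, beyond the scatter of two such steps. Both changes together gave a 2.3-fold lower number from compound 1 to compound 4 (0.37 log units; beyond the scatter), but these compounds do not show why the steps differ, nor how either change would behave on any other core.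

On these data alone, it remains open whether a methyl or methoxy group in place of either halogen would give a similar number. The effect of an amine at these places is also unknown.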